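The source may report more compounds than this note shows. Statements on the series, on what has been measured and on what is new or still open speak of the compounds shown alone.

Working notes on the series.

Going by the values given here, compound 1 `COc1cc(/C=C/C(=O)c2cccc(-n3cc(-c4ccc(Cl)cc4)[nH]c3=O)c2)cc(OC)c1OC` and compound 2 `O=C(/C=C/c1cccc(O)c1)c1cccc(-n2cc(-c3ccc(Cl)cc3)[nH]c2=O)c1` share a core and differ at the aryl end of the enone, so no single-point step between them is available; their two values are simply set side by side. In a functional assay on ACHN cells (Homo sapiens) for inhibition (a lower number here means a stronger inhibitor of growth, a higher number a weaker inhibitor of growth), compound 1 gives 7170 nM, which is the highest of the two numbers in hand. Compound 2 gives 1840 nM in this assay, a lower number, and the gap between the two lies beyond the scatter.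

Compound 3 `COc1ccc(-c2cn(-c3cccc(C(=O)/C=C/c4cc(OC)c(OC)c(OC)c4)c3)c(=O)[nH]2)cc1` is compound 1 with one change at the other end of the molecule: methoxy in place of chloro on an aromatic carbon, para to a large group. No measured pair in the series carries this exchange, so the direction of the step is not fixed by any shown number. The expectation is a step of small size from compound 1 to compound 3, most likely not beyond the scatter, and the estimated change is a 1.2-fold lower number from compound 1 to compound 3 (0.08 log units; within the scatter) in this assay. Compound 3 is therefore expected to give about 6000 nM in this assay, with the estimate ranging from 2000 nM to 20000 nM.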

Compound 3, concentration for 50% growth inhibition: 1820 nM
The estimate for compound 3 lay 3.3-fold (0.52 log units) above the measured number; measured number below the stated range.
By their numbers in this assay, from the lowest: compounds 3 and 2 (each within the scatter of the next); then compound 1.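

Going by these compounds alone, at this position, on an aromatic carbon para to a large group, methoxy in place of chloro gives the first single-point step: in this assay, it is a 3.9-fold lower number from compound 1 to compound 3 (0.60 log units; beyond the scatter). The earlier values differed only at the aryl end of the enone and could not show whether the other end of the molecule affects growth inhibition; this pair shows that it does, since the 4-chlorophenyl to 4-methoxyphenyl change alone, with the rest of compound 1 unchanged, moves the number beyond the scatter. No supporting data are at hand to explain the step.

Going by these compounds, the step rests on a single pair, so it remains open whether the same exchange would move the number in the same direction and by a similar size with the aryl end of compound 2 in place of that of compound 1. The compounds shown also leave open how an amine, a carboxylic acid or a longer alkoxy chain such as butoxy at this position would read in this assay.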